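Amide replacement on the amine of a quinuclidine substance-P ligand

The source may hold more compounds than are shown below. What is called first, only, known or untested is meant among the compounds shown, and "the series" means these compounds.

Compound 1 `FC(F)(F)c1ccccc1CN[C@@H]1C2CCN(CC2)[C@@H]1C(c1ccccc1)c1ccccc1`: 33 nM
Compound 2 `Clc1ccccc1CCCN[C@@H]1C2CCN(CC2)[C@@H]1C(c1ccccc1)c1ccccc1`: 1100 nM

In an assay on membranes from Cerebral cortex for binding affinity to Substance-P receptor (Cavia porcellus), read by radioligand binding (on this read-out lower numbers stand for stronger inhibition and higher numbers for weaker inhibition), compound 2 gives the higher of the two numbers, and the nearest measured neighbour is compound 1. Within the data shown here, the single measured step, a 33-fold higher number from compound 1 to compound 2 (1.52 log units; beyond the scatter), shows that the group carried by the amine nitrogen on the shared core is where the binding changes strongly. Compound 3 `O=C(N[C@@H]1C2CCN(CC2)[C@@H]1C(c1ccccc1)c1ccccc1)c1ccccc1Cl` continues along this nitrogen: (2-chlorophenyl)carbonyl in place of 3-(2-chlorophenyl)propyl on an amine nitrogen. Among the measured compounds shown here, no measured pair contrasts an amide with an amine on this position, so the step to compound 3 has no direct precedent; the one measured step only shows that changes here can be large in either direction. Weighing this, the step from compound 2 to compound 3 is expected to be a 1.4-fold higher number from compound 2 to compound 3 (0.13 log units; within the scatter), that is, not clearly beyond the scatter, but with considerable uncertainty. Compound 3 is therefore estimated at 1500 nM in this assay, with a range from 300 nM to 8000 nM.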

Compound 3, half-maximal inhibitory concentration: > 10000 nM
Compound 3: only a limit was reported; the forecaster's own chance of this, stated with the estimate: 15%; at least 6.6-fold (0.82 log units) between middle value and limit.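

In this assay compound 3 is reported only as a limit of the assay, not as a number: the limit of > 10000 nM in this assay, at which 1 of the 3 values shown sits. Even so, placing (2-chlorophenyl)carbonyl in place of 3-(2-chlorophenyl)propyl on the amine nitrogen gives an at least 9.0-fold higher number from compound 2 to compound 3 (0.95 log units; beyond the scatter), so the change is beyond the scatter and runs in the same direction as the earlier step between the two amines. Set against the best compound shown, the replacement of 2-(trifluoromethyl)benzyl by (2-chlorophenyl)carbonyl gives an at least 300-fold higher number from compound 1 to compound 3 (2.48 log units; beyond the scatter), which shows for the first time that an amide on this nitrogen, and not only a different amine substituent, can take binding on the shared core out of the measurable range.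

The change from compound 2 to compound 3 alters both the carbonyl and the length of the chain to the aromatic ring, and the change from compound 1 to compound 3 also exchanges trifluoromethyl for chlorine, so the share of the carbonyl itself stays unresolved. As far as these compounds go, a 2-chlorobenzyl group on the amine nitrogen, or a 2-(trifluoromethyl)benzoyl amide, would separate these contributions, and how far the amide result extends to a sulfonamide on this nitrogen remains open.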